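The source may hold more compounds than are shown below. What is called first, only, known or untested is meant among the compounds shown, and "the series" means these compounds.

Compound 1 `O=C(CCCCC1CCSS1)Nc1ccc(Br)cn1` carries a ring at the far end of its chain, away from the carbonyl. In a functional assay on KB cells (Homo sapiens) for inhibition, read by MTT assay, with a stated time of 24 h, tested at 1 ug/mL (on this read-out higher numbers stand for more inhibition of growth at the one concentration tested and lower numbers for less inhibition of growth), compound 1 gives 4.33%. Compound 3 `O=C(CCCCC(S)CCS)Nc1ccc(Br)cn1` is its ring-opened partner: a group of 5 heavy atoms (3 carbon, 2 sulfur; no ring) in place of a group of 5 heavy atoms (3 carbon, 2 sulfur; one five-membered non-aromatic ring with 2 hetero atoms), on a saturated chain carbon, four bonds along the chain from a carbonyl carbon. In this assay compound 3 gives 2.51%, and the step of a number 1.8 percentage points lower from compound 1 to compound 3 (within the scatter) shows that opening the ring left the read-out essentially where it was. Compound 2 `O=C(CCCCC1CCSS1)Nc1cccc2ccccc12` has a different core from compound 1; how the two cores differ is not broken down here. In this assay compound 2 gives 8.37%. Compound 4 `O=C(CCCCC(S)CCS)Nc1cccc2ccccc12` is compound 2 with the same change applied: a group of 5 heavy atoms (3 carbon, 2 sulfur; no ring) in place of a group of 5 heavy atoms (3 carbon, 2 sulfur; one five-membered non-aromatic ring with 2 hetero atoms), on a saturated chain carbon, four bonds along the chain from a carbonyl carbon, the same change as between compound 1 and compound 3, at the same place on the chain. Nothing has been measured yet for compound 4. Because the step of a number 1.8 percentage points lower from compound 1 to compound 3 (within the scatter) lay within the scatter, the expected step of a number 1.4 percentage points lower from compound 2 to compound 4 (within the scatter) is taken to be small as well. Compound 4 is therefore estimated at 7%, with a likely range from 0% to 16% in this assay.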

Compound 4, percent growth inhibition at one concentration: "not active" (no number reported)
Compound 4 has no reported number here; no gap can be computed for the estimate.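

In this assay, going by these compounds alone, compound 4 is reported as "not active" (no number reported), so no step from compound 2 to compound 4 can be read. The compounds shown leave open whether swapping the ring for 1,3-disulfanylpropyl changes growth inhibition on the core of compound 2. No measurement shown here offers an explanation for this result.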